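The compounds below may be only part of what the source reports. "The series", "measured", "known", "first", "only" and "open" are said of these compounds alone.

Measured so far:
compound 1 `O=C(O)CCC/C=C\CC1=CCC[C@@H]1NS(=O)(=O)c1ccccc1` – 2300 nM
compound 2 `O=C(O)CC/C=C\CC1=CCC[C@@H]1NS(=O)(=O)c1ccc(F)cc1F` – 20000 nM

In a functional assay on a cell-free system (plasma) for inhibition of thromboxane A2 receptor (Homo sapiens), read by turbidimetry (on this read-out lower numbers stand for stronger inhibition and higher numbers for weaker inhibition), compound 2 gives the highest of the two numbers; its nearest neighbour is compound 1, which gives a clearly lower number in this assay, beyond the usual scatter. Compound 3 `O=C(O)CC/C=C\CC1=CCC[C@@H]1NS(=O)(=O)c1ccccc1` has not yet been measured. It differs from compound 2 by phenyl in place of 2,4-difluorophenyl on a sulfonyl sulfur. Among the compounds with values here, no measured pair shows this change on its own, so the direction rests on little. A modest decrease in the number is expected from compound 2 to compound 3, a 2.5-fold lower number from compound 2 to compound 3 (0.40 log units; beyond the scatter), near the edge of scatter. Compound 3 is estimated at 8000 nM, in the range 2500 nM to 25000 nM.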

Compound 3, half-maximal inhibitory concentration: 2200 nM
Beside the measured number, compound 3's estimate is 3.6-fold (0.56 log units) above it; the measured number lies below the stated range.
By their numbers in this assay, from the lowest: compounds 3 and 1 (each within the scatter of the next); then compound 2.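

In this assay, phenyl in place of 2,4-difluorophenyl on a sulfonyl sulfur gives a 9.1-fold lower number from compound 2 to compound 3 (0.96 log units; beyond the scatter) in a single change, so this position clearly responds to the swap. Carboxy in place of carboxymethyl on a saturated chain carbon gives a 1.0-fold lower number from compound 1 to compound 3 (0.02 log units; within the scatter) and so shows no real difference with phenyl on the sulfonyl sulfur. Nothing available explains either step.

Going by these compounds, whether a single fluorine or a methoxy group on the phenyl would track phenyl or 2,4-difluorophenyl remains open. So does whether the chain change stays silent with 2,4-difluorophenyl present.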